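The source may report more compounds than this note shows. Statements on the series, on what has been measured and on what is new or still open speak of the compounds shown alone.

Measured compounds in an ADME assay on BCBL1 cells (Homo sapiens) for cytotoxicity, with a stated time of 7 days; on this read-out lower numbers stand for higher toxicity in this test and higher numbers for lower toxicity in this test:
Compound 1 `Nc1nc(N2CCCC2)c2ncn(/C=C3/CC3(CO)CO)c2n1` — the value reported for compound 1 is a limit of the assay, > 20000 nM.
Compound 2 `CCCCCCOc1nc(N)nc2c1ncn2/C=C1/CC1(CO)CO` — for compound 2 only a limit is reported, > 20000 nM.
Compound 3 `CCCCOc1nc(N)nc2c1ncn2/C=C1/CC1(CO)CO` — for compound 3 the value is likewise a limit, > 20000 nM.

Where compound 1 stands: only a limit is known for compound 1 in this assay, and the same holds for the other two measured compounds, so no number places compound 1 among them. The step from compound 1 to compound 4 `CNc1nc(N)nc2c1ncn2/C=C1/CC1(CO)CO` alters one group on the shared core: methylamino in place of pyrrolidin-1-yl on an aromatic carbon. The measured steps starting from compound 1 at the same group are a step that the two limits leave unreadable from compound 1 to compound 2 and a step that the two limits leave unreadable from compound 1 to compound 3; the third step, a step that the two limits leave unreadable from compound 2 to compound 3, is equally unreadable. All three values sit at the limit of > 20000 nM in this assay, at which 3 of the 3 values shown sit. Nothing in the series therefore shows any readable movement in this assay when this group is exchanged, and no step beyond the scatter is expected in either direction for compound 4. Compound 4 is expected to come out at 40000 nM, with a range of 15000 nM to 150000 nM, and most probably reported again only as a limit. The implied step that the limit leaves unreadable from compound 1 to compound 4 is expected to be one that the limits leave unreadable.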

Compound 4, half-maximal cytotoxic concentration: 67000 nM
For compound 4 the middle estimate is 1.7-fold (0.22 log units) below the measured one, and the stated range covers the measured number.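

In this assay compound 4 gives 67000 nM. The steps from compound 1, compound 2 and compound 3 to compound 4 cannot be read, since those three compounds are reported only as a limit: the limit of > 20000 nM in this assay, at which 3 of the 4 values shown sit.

The compounds shown leave open whether exchanging this group on the shared core moves the read-out at all, in either direction.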